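Trading a Methyl for a Chlorine on the Benzyl Arm

The compounds below may be only part of what the source reports. "The series", "measured", "known", "first", "only" and "open" are said of these compounds alone.

Measured so far:
compound 1 `C=C(Br)C(=O)Nc1ccc(/C=C2\SC(=O)N(Cc3ccc(C)cc3)C2=O)cc1` — 6100 nM
compound 2 `C=C(Br)C(=O)Nc1cccc(/C=C2\SC(=O)N(Cc3ccc(C(F)(F)F)cc3)C2=O)c1` — 870 nM
compound 3 `Nc1cccc(/C=C2\SC(=O)N(Cc3ccccc3)C2=O)c1` — > 250000 nM (a limit)

In a functional assay on FM3A cells (Mus musculus) for cytotoxicity, read by cell counting, with a stated time of 2 days (on this read-out lower numbers stand for stronger inhibition and higher numbers for weaker inhibition), compound 1 gives 6100 nM, the higher of the two numbers available. Compound 2 gives 870 nM, a lower number whose gap to compound 1 lies beyond the usual scatter. Compound 3 sits at the limit of > 250000 nM in this assay, at which 1 of the 3 values shown sits, so for it no number exists, only a boundary of this assay.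

Compound 4 `C=C(Br)C(=O)Nc1ccc(/C=C2\SC(=O)N(Cc3cccc(Cl)c3)C2=O)cc1` differs from compound 1 in one place: 3-chlorophenyl in place of 4-methylphenyl on a saturated chain carbon bound to an amide-type nitrogen in a ring. Within the data shown here, no measured pair shows this exact change, so the step from compound 1 to compound 4 is expected to be small, a 1.4-fold lower number from compound 1 to compound 4 (0.13 log units; within the scatter), likely within or barely past the scatter and without a clear direction. Compound 4 is therefore estimated at 4500 nM, with a plausible range from 1500 nM to 15000 nM.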

Compound 4, half-maximal inhibitory concentration: 6100 nM
The estimate for compound 4 lay 1.4-fold (0.13 log units) below the measured number; the range from low to high includes it.
By their numbers in this assay, from the lowest: compound 2; then compounds 1 and 4 (each within the scatter of the next). At a limit, above all of these: compound 3.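

In this assay, among these compounds, the step to 3-chlorophenyl in place of 4-methylphenyl shows no change at the digits printed from compound 1 to compound 4 (within the scatter) and gives the first reading of a single change on this benzyl arm. With the rest of the structure held fixed, this read-out does not distinguish these two groups. Nothing available explains why the two groups read alike. The compounds shown leave open whether an amine or a carboxylic acid on this aromatic ring would shift the number. They also leave open what a longer chain carrying the ring would do.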